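The source may report more compounds than this note shows. Statements on the series, on what has been measured and on what is new or still open speak of the compounds shown alone.

In an ADME assay on S9 fraction from liver (Homo sapiens) for metabolic stability, read by LC-MS, using NADPH, with a stated time of 60 min, tested at 1 uM (a lower number here means that the compound disappears faster, a higher number that the compound lasts longer), the series so far reads:
- compound 1 `Cc1ccccc1N(C)C(=O)c1ccc(-c2ccc(OS(N)(=O)=O)cc2)o1` gives 0.783 h
- compound 2 `Cc1ccc(F)cc1N(C)C(=O)c1ccc(-c2ccc(OS(N)(=O)=O)cc2)o1` gives 0.567 h
- compound 3 `Cc1cc(F)ccc1N(C)C(=O)c1ccc(-c2ccc(OS(N)(=O)=O)cc2)o1` gives 0.733 h

Compound 3 lies within the scatter of both compound 1 and compound 2, and no order among the three can be read. Compound 4 `Cc1c(F)cccc1N(C)C(=O)c1ccc(-c2ccc(OS(N)(=O)=O)cc2)o1` is not yet measured. It carries 3-fluoro-2-methylphenyl in place of 4-fluoro-2-methylphenyl on an amide-type nitrogen. Within the data shown here, three measured steps bear on this, all within the scatter. Two are fluoro in place of hydrogen on an aromatic carbon (a 1.4-fold lower number from compound 1 to compound 2 (0.14 log units; within the scatter)) and (a 1.1-fold lower number from compound 1 to compound 3 (0.03 log units; within the scatter)). The closest parallel is 4-fluoro-2-methylphenyl in place of 5-fluoro-2-methylphenyl (a 1.3-fold higher number from compound 2 to compound 3 (0.11 log units; within the scatter)). No step beyond the scatter is expected in this assay, and the estimated step is small (a 1.1-fold lower number from compound 3 to compound 4 (0.03 log units; within the scatter)). The estimate for compound 4 is 0.68 h, with an expected range of 0.42 h to 1.05 h.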

Compound 4, half-life: 0.35 h
Beside the measured number, compound 4's estimate is 1.9-fold (0.29 log units) above it; measured number outside the range, below it.
By their numbers in this assay, from the lowest: compounds 4, 2, 3 and 1 (each within the scatter of the next, the first and the last beyond it).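

In this assay the fluoro's location alone now matters: 3-fluoro-2-methylphenyl in place of 4-fluoro-2-methylphenyl on the amide-type nitrogen gives a 2.1-fold lower number from compound 3 to compound 4 (0.32 log units; beyond the scatter) and passes the scatter, though the two compounds have the same atoms. Among these compounds, the step of a 2.2-fold lower number from compound 1 to compound 4 (0.35 log units; beyond the scatter) is the first fluoro in place of hydrogen to pass the scatter, whereas a 1.6-fold lower number from compound 2 to compound 4 (0.21 log units; within the scatter) stays within it. Nothing measured here bears on the cause of these steps.

From the compounds shown here alone, whether chloro in place of this fluoro would track compound 4 remains open.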